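The compounds below may be only part of what the source reports. "The series", "measured", "known", "first", "only" and "open" are said of these compounds alone.

Compound 1, with the structure `CCC1=C(O)c2c(oc(-c3ccccc3)cc2=O)C(CC)(CC)C1=O`, was examined in a functional assay on KB cells (Homo sapiens) for antiproliferative activity, read by sulforhodamine B assay, with a stated time of 3 days; on this read-out lower numbers stand for an effect already at smaller amounts and higher numbers for an effect only at larger amounts of compound. In this assay compound 1 gives > 236 uM, which is a limit of the assay and not a measured number. Compound 2, `CCCc1ccc(-c2cc(=O)c3c(o2)C(CC)(CC)C(=O)C(CC)=C3O)cc1`, carries a propyl in place of hydrogen on an aromatic carbon, and in this assay compound 2 gives > 53 uM, also a limit. Compound 3, `CCC1=C(O)c2c(oc(-c3cccc(OC(F)(F)F)c3)cc2=O)C(CC)(CC)C1=O`, carries a trifluoromethoxy in place of hydrogen on an aromatic carbon, and compound 3 gives > 47.4 uM, again a limit. The step that the two limits leave unreadable from compound 1 to compound 2 and the step that the two limits leave unreadable from compound 1 to compound 3 thus have no readable size, because each rests on the limit of > 236 uM in this assay, at which 1 of the 3 values shown sits, together with the limit of > 53 uM in this assay, at which 1 of the 3 values shown sits, or (the limit of > 47.4 uM in this assay, at which 1 of the 3 values shown sits).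

Compound 4, `CCC1=C(O)c2c(oc(-c3cccc(F)c3)cc2=O)C(CC)(CC)C1=O`, differs from compound 1 by fluoro in place of hydrogen on an aromatic carbon, the same kind of small change as in the two measured steps. Those steps give no readable size, so no step beyond the scatter is expected here either, and a further limit seems the most likely outcome. Compound 4 is therefore estimated at 150 uM, within 40 uM to 600 uM. The step of an at least 1.5-fold lower number from compound 1 to compound 4 (0.19 log units; that floor lies within the scatter) is expected to be small.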

Compound 4, concentration for half-maximal effect: > 56.2 uM
Compound 4: only a limit was reported (the forecaster's own chance of this, stated with the estimate: 75%); the middle value is on the limit's open side.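

Compound 4 gives > 56.2 uM, which is a limit of the assay and not a measured number. Its steps to compound 1, compound 2 and compound 3 therefore cannot be read. The compounds shown leave open whether any of these aromatic ring changes shifts the antiproliferative effect at all.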